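Cytotoxicity Limits in an Amide Series, Third Compound Awaited

The source may report more compounds than this note shows. Statements on the series, on what has been measured and on what is new or still open speak of the compounds shown alone.

Compound 1 `COc1ccc(-c2cnc(NC(=O)c3cccc(OC)c3)n2C)cc1` gives in a toxicity assay on THP-1 cells (Homo sapiens) for inhibition (on this read-out higher numbers stand for lower toxicity in this test and lower numbers for higher toxicity in this test), only the limit > 100000 nM.
Compound 2 `COc1ccc(-c2cnc(NC(=O)C3CCCC3)n2C)cc1` gives in this assay only the limit > 100000 nM.

For the measured compounds named here, both measured values sit at the same limit (the limit of > 100000 nM in this assay, at which 2 of the 2 values shown sit), so the single measured step that the two limits leave unreadable from compound 1 to compound 2 cannot be sized. Compound 2 therefore stands at that limit rather than at a number. Compound 3 `COc1ccc(-c2cnc(NC(=O)c3ccccc3OC)n2C)cc1` differs from it by 2-methoxyphenyl in place of cyclopentyl on a carbonyl carbon. No readable step bears on this change; the expected step that the limit leaves unreadable from compound 2 to compound 3 is none beyond the scatter. Compound 3 is expected near 120000 nM, within 50000 nM to 300000 nM, most likely again as a limit.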

Compound 3, half-maximal cytotoxic concentration: > 100000 nM
Compound 3 gave a limit, no number; the forecaster's own chance of this, stated with the estimate: 80%; the middle value does not contradict the limit.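

No step can be read among compound 1, compound 2 and compound 3, as each gives only a limit: the limit of > 100000 nM in this assay, at which 3 of the 3 values shown sit.

The compounds shown leave open whether changing the group on the carbonyl carbon alters toxicity in this assay at all.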